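A few compounds are considered here, and "the series" means these few. Any claim that something is new, unique, unknown or untested is made for them only; others in the source may bear on it.

Measured so far:
Compound 1 `ClCc1ccccc1Cn1cnc2c(Cl)nc(Cl)nc21` gives 6760 nM in a functional assay on NCI-H522 cells (Homo sapiens) for cytotoxicity, read by sulforhodamine B assay, with a stated time of 48 h; a higher number here means that more compound is tolerated, a lower number that less compound is tolerated.
Compound 2 `ClCc1ccccc1Cn1cnc2c(Cl)ncnc21` reaches only the limit of the assay, > 100000 nM, in this assay.
Compound 3 `ClCc1cccc(Cn2cnc3ncnc(Cl)c32)c1` likewise reaches only the limit, > 100000 nM, in this assay.

Compound 2 and compound 1 differ in one place: chloro in place of hydrogen on an aromatic carbon. That change brings an at least 14-fold lower number from compound 2 to compound 1 (1.17 log units; beyond the scatter). Compound 3 and compound 2 are built from the same atoms joined differently; how the two cores differ is not broken down here. Compound 4 `ClCc1cccc(Cn2cnc3nc(Cl)nc(Cl)c32)c1`, not yet measured, carries the same change at the same place: chloro in place of hydrogen on an aromatic carbon. Since two of the three values sit at the limit (the limit of > 100000 nM in this assay, at which 2 of the 3 values shown sit), the earlier step is known only as a lower bound. For compound 4 a comparable fall is expected, estimated as an at least 6.6-fold lower number from compound 3 to compound 4 (0.82 log units; beyond the scatter) in this assay, resting on an at least 14-fold lower number from compound 2 to compound 1 (1.17 log units; beyond the scatter). Compound 4 is estimated near 15000 nM, expected between 4000 nM and 100000 nM.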

Compound 4, concentration lethal to 50% of the cells: 6910 nM
For compound 4 the middle estimate is 2.2-fold (0.34 log units) above the measured one; measured number inside the range.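

In this assay, putting chloro in place of hydrogen on the aromatic carbon between two ring nitrogen atoms brings an at least 14-fold lower number from compound 3 to compound 4 (1.16 log units; beyond the scatter), so this change carries over to a second core among the compounds shown. Set beside the earlier step, it looks similar, but this does not show that the two steps are equal: the same change on two cores in this assay, an at least 14-fold lower number (1.17 log units; beyond the scatter) from compound 2 to compound 1 and an at least 14-fold lower number (1.16 log units; beyond the scatter) from compound 3 to compound 4; the limit leaves it open whether they differ. On these data alone, the true size of each step also stays unknown, since each starting compound gives only a limit and not a number: the limit of > 100000 nM in this assay, at which 2 of the 4 values shown sit.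

The compounds shown leave open whether an amine or a bromo group at this place would bring a similar change. Every compound shown also carries the chloromethyl group, so the effect of a plain methyl group there remains open.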